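Urotensin-2 receptor efficacy series: ester to carbamate step

A few compounds are considered here, and "the series" means these few. Any claim that something is new, unique, unknown or untested is made for them only; others in the source may bear on it.

Measured in an assay on NIH3T3 cells with Urotensin-2 receptor (Homo sapiens) as the target; a higher number here means a larger maximal response, a lower number a smaller maximal response:
compound 1 `COc1ccc(C(=O)OC(CCN(C)C)c2ccc(Cl)cc2)cc1` gives 84%
compound 2 `Cc1ccc(C)c(C(=O)OC(CCN(C)C)c2ccc(Cl)cc2)c1` gives 86%
compound 3 `Cc1ccc(C(=O)OC(CCN(C)C)c2ccc(Cl)cc2)cc1` gives 56%

Compound 3 stands lowest of the three in this assay; the others lie a number 2 percentage points higher from compound 1 to compound 2 (within the scatter) of each other, and both sit well above it: a number 28 percentage points lower from compound 1 to compound 3 (beyond the scatter) and a number 30 percentage points lower from compound 2 to compound 3 (beyond the scatter).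

Compound 4 `CN(C)CCC(OC(=O)NCc1ccccc1)c1ccc(Cl)cc1` carries benzylamino in place of 4-methylphenyl on a carbonyl carbon. Going by the values given here, both measured steps that replace the 4-methylphenyl of compound 3 raise the maximal response by a modest amount, but neither introduces a benzylamino group, so no measured step bears directly on this change. The expectation is a modest rise with wide uncertainty: compound 4 is estimated at 70% (range 45% to 95%), an expected step of a number 14 percentage points higher from compound 3 to compound 4 (beyond the scatter).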

Compound 4, largest response reached (reported as efficacy), in percent of the reference or control that the assay uses: 180%
The estimate for compound 4 lay 110 percentage points below the measured number; measured number outside the range, above it.
By their numbers in this assay, from the lowest: compound 3; then compounds 1 and 2 (each within the scatter of the next); then compound 4.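

Replacing each aromatic group on the carbonyl carbon with benzylamino gives a number 124 percentage points higher from compound 3 to compound 4 (beyond the scatter) and a number 94 percentage points higher from compound 2 to compound 4 (beyond the scatter) and a number 96 percentage points higher from compound 1 to compound 4 (beyond the scatter) in this assay and shows that this position can carry far more response than the three esters revealed. Among the listed compounds, the change from ester to carbamate is the largest step at this position. Nothing measured here explains the size of this step.

From the compounds shown here alone, whether the step follows the carbamate nitrogen or the benzyl ring remains open. Phenethyl or methyl(benzyl)amino on the same carbonyl carbon would help separate the two.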